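A few compounds are considered here, and "the series" means these few. Any claim that something is new, unique, unknown or untested is made for them only; others in the source may bear on it.

In a functional assay on CNE-2 cells (Homo sapiens) for inhibition, read by MTT assay, with a stated time of 72 h (a lower number here means a stronger inhibitor, a higher number a weaker inhibitor), the measured compounds read as follows

Compound 1 `CNC(=O)CCCCCCCn1nc(-c2cnc3[nH]ccc3c2)c2c(N)ncnc21` gives 8990 nM
Compound 2 `Nc1ncnc2c1c(-c1cnc3[nH]ccc3c1)nn2CCCCC(=O)NO` gives > 150000 nM, which is a limit of the assay
Compound 3 `Nc1nc2cc(-c3nn(CCCCCCCCCC(=O)NO)c4ncnc(N)c34)ccc2o1` gives 36800 nM

Of the two actual numbers, compound 3 holds the higher, and compound 1 lies lower by more than the scatter. The move to compound 4 `Nc1nc2cc(-c3nn(CCCCCCC(=O)NO)c4ncnc(N)c34)ccc2o1` is hydroxycarbamoyl in place of 3-(hydroxycarbamoyl)propyl on a saturated chain carbon, six bonds along the chain from an aromatic nitrogen, putting hydroxycarbamoyl in place of 3-(hydroxycarbamoyl)propyl on a saturated chain carbon, six bonds along the chain from an aromatic nitrogen. Within the data shown here, the one measured step that bears on this, an at least 16-fold higher number from compound 1 to compound 2 (1.22 log units; beyond the scatter), is large, but it also changes the end group and belongs to a different core. It is therefore a weak guide, and no step beyond the scatter is expected in this assay for this change. The expected step is a 1.5-fold lower number from compound 3 to compound 4 (0.17 log units; within the scatter) in size. For compound 4 the estimated value is 25000 nM, with an expected range from 3000 nM to 120000 nM in this assay.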

Compound 4, half-maximal inhibitory concentration: 4360 nM
Estimate against measurement, compound 4: 5.7-fold (0.76 log units) above, and the stated range covers the measured number.
By their numbers in this assay, from the lowest: compound 4; then compound 1; then compound 3. At a limit, above all of these: compound 2.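

Cutting the chain on the shared core in this assay gives an 8.4-fold lower number from compound 3 to compound 4 (0.93 log units; beyond the scatter), with the hydroxycarbamoyl end group kept. Chain length at this position therefore moves the number beyond the scatter by itself, which the earlier step could not show, as it also changed the end group and belonged to a different core. No measurement shown here gives a reason for this step. Going by these compounds, whether a still shorter chain would lower the number further on this core remains open. So does the effect of a carboxylic acid or an amine at the chain end.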